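A few compounds are considered here, and "the series" means these few. Any claim that something is new, unique, unknown or untested is made for them only; others in the source may bear on it.

Notes on the series.

Going by the values given here, compound 3 `c1ccc2c(-c3cn4ccnc4c(-c4ccc5ncn(C6CCCCC6)c5c4)n3)cccc2c1` gives 23% in a functional assay on UO-31 cells (Homo sapiens) for inhibition, read by sulforhodamine B assay, with a stated time of 48 h, tested at 10 uM (on this read-out higher numbers stand for more inhibition at the one concentration tested (going by the name of the read-out) and lower numbers for less inhibition), the lowest of the three numbers so far. Compound 1 `Brc1cn2ccnc2c(-c2ccc3ncn(C4CCCCC4)c3c2)n1` gives 37.6% in this assay, and compound 2 `c1ccc(-c2cn3ccnc3c(-c3ccc4ncn(C5CCCCC5)c4c3)n2)cc1` gives 55.2%. The measured steps show a number 17.6 percentage points higher from compound 1 to compound 2 (beyond the scatter), a number 14.6 percentage points lower from compound 1 to compound 3 (beyond the scatter) and a number 32.2 percentage points lower from compound 2 to compound 3 (beyond the scatter); the last of these lies beyond the scatter and is the one that matters here.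

Compound 4 `CC(=O)c1ccc(-c2cn3ccnc3c(-c3ccc4ncn(C5CCCCC5)c4c3)n2)cc1` differs from compound 3 by the change (4-acetylphenyl in place of naphthalen-1-yl on an aromatic carbon). The relevant precedent is the step of a number 32.2 percentage points lower from compound 2 to compound 3 (beyond the scatter), in which a single six-membered aromatic ring of carbon only was replaced by naphthalen-1-yl and the number fell by a large amount. Among the compounds with values here, the present change runs in the opposite sense, back to one such ring, now carrying an acetyl group; no measured pair shows what the acetyl group alone does. On that basis a rise beyond the scatter is expected, roughly undoing the fall, with the acetyl group left as an open question. The estimated step is a number 25 percentage points higher from compound 3 to compound 4 (beyond the scatter). Compound 4 is therefore expected to give about 48%, within a range of 33% to 63%.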

Compound 4, a percentage reported as inhibition, at one concentration (the size of the read-out at that concentration, not a potency): 23.1%
Beside the measured number, compound 4's estimate is 24.9 percentage points above it, outside the stated range (below it).
By their numbers in this assay, from the lowest: compounds 3 and 4 (each within the scatter of the next); then compound 1; then compound 2.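

In this assay, 4-acetylphenyl in place of naphthalen-1-yl leaves the number within the scatter (a number 0.1 percentage points higher from compound 3 to compound 4 (within the scatter)), while acetyl in place of hydrogen on the phenyl ring of compound 2 is a large change (a number 32.1 percentage points lower from compound 2 to compound 4 (beyond the scatter)), so at this position a single six-membered aromatic ring of carbon only does not by itself give the higher number of compound 2. Against the bromo compound the change is modest (a number 14.5 percentage points lower from compound 1 to compound 4 (beyond the scatter)), which places 4-acetylphenyl, like naphthalen-1-yl, lower than bromo at this position. Nothing available accounts for these steps.

Whether the fall is specific to acetyl remains open, since the phenyl ring is shown with no other substituent. A phenyl ring carrying an amine, a carboxylic acid or a methoxy group at this place would test that.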